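Changing the Side Chain of a Well-Tolerated Compound

The source may hold more compounds than are shown below. What is called first, only, known or untested is meant among the compounds shown, and "the series" means these compounds.

Here three compounds share one core and differ only in one side chain: compound 1 (`CCCCNc1cc(Oc2c(OC)cc3cc(C#N)ccc3c2OC)nc(Nc2ccc(C#N)cc2)n1`), compound 2 (`COc1cc2cc(C#N)ccc2c(OC)c1Oc1cc(NCC(C)(C)C)nc(Nc2ccc(C#N)cc2)n1`) and compound 3 (`COc1cc2cc(C#N)ccc2c(OC)c1Oc1cc(NCC2CCOC2)nc(Nc2ccc(C#N)cc2)n1`). All three were tested in an ADME assay on MT4 cells (Homo sapiens) for cytotoxicity, read by MTT assay, with a stated time of 5 days; a higher number here means that more compound is tolerated, a lower number that less compound is tolerated.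

Compound 1 gives > 125000 nM as a limit of the assay, not a number. Compound 2 gives > 125000 nM as a limit too. Compound 3 gives > 125000 nM as a limit too. Compound 3 therefore stands with the rest of the set (the limit of > 125000 nM in this assay, at which 3 of the 3 values shown sit).

Compound 4 (`COc1cc2cc(C#N)ccc2c(OC)c1Oc1cc(N2CCC(O)C2)nc(Nc2ccc(C#N)cc2)n1`) differs from compound 3 in one place (3-hydroxypyrrolidin-1-yl in place of ((oxolan-3-yl)methyl)amino on an aromatic carbon). In words, 3-hydroxypyrrolidin-1-yl takes the place of ((oxolan-3-yl)methyl)amino on an aromatic carbon.

Three measured swaps bear on this change: a step that the two limits leave unreadable from compound 1 to compound 2 and a step that the two limits leave unreadable from compound 1 to compound 3 and also a step that the two limits leave unreadable from compound 2 to compound 3 with no size to quote. None of them brings in a 3-hydroxypyrrolidin-1-yl group, so they guide the expectation only loosely. Still, every side chain tried so far ends at the same limit, so no shift beyond the usual scatter is expected.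

In this assay the expected result is an at least 1.2-fold lower number from compound 3 to compound 4 (0.09 log units; that floor lies within the scatter) and nothing larger is expected. Compound 4 is estimated at 100000 nM (expected range 25000 nM to 125000 nM), and it may well be reported as a limit again.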

Compound 4, half-maximal cytotoxic concentration: > 125000 nM
Compound 4 gave a limit, no number; the forecaster's own chance of this, stated with the estimate: 70%; middle value at least 1.2-fold (0.09 log units) from the limit.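

Compound 4 gives a limit, not a number, so its steps from compound 1, compound 2 and compound 3 cannot be read, and all four compounds stay together: the limit of > 125000 nM in this assay, at which 4 of the 4 values shown sit. The compounds shown leave open whether these four side chains differ at all in how much compound is tolerated, and what kind of side chain would give a readable number.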